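A trifluoromethyl swap in a small antiproliferative series

The source may report more compounds than this note shows. Statements on the series, on what has been measured and on what is new or still open speak of the compounds shown alone.

Compound 1 (`O=S(=O)(c1ccc(F)cc1)n1c(-c2cn(-c3ccccc3)nc2-c2ccc(F)cc2)nc2ccccc21`) gives 2440 nM
Compound 2 (`O=S(=O)(c1ccc(Br)cc1)n1c(-c2cn(-c3ccccc3)nc2-c2ccc(F)cc2)nc2ccccc21`) gives 2040 nM
Compound 3 (`O=S(=O)(c1ccc(C(F)(F)F)cc1)n1c(-c2cn(-c3ccccc3)nc2-c2ccc(F)cc2)nc2ccccc21`) gives 1430 nM

All three were read in a functional assay on HeLa cells (Homo sapiens) for antiproliferative activity, read by MTT assay, with a stated time of 24 h (on this read-out lower numbers stand for stronger inhibition and higher numbers for weaker inhibition), and lie within the scatter of each other. Compound 2 stands among them without separation, as a 1.2-fold lower number from compound 1 to compound 2 (0.08 log units; within the scatter) and a 1.4-fold lower number from compound 2 to compound 3 (0.15 log units; within the scatter) show. Compound 4 (`O=S(=O)(c1ccc(Br)cc1)n1c(-c2cn(-c3ccccc3)nc2-c2ccc(C(F)(F)F)cc2)nc2ccccc21`) differs from compound 2 by one change (trifluoromethyl in place of fluoro on an aromatic carbon), trifluoromethyl in place of fluoro on an aromatic carbon. Among the measured compounds shown here, no step at that place has been measured. The nearest evidence is the same replacement made elsewhere in the molecule, where a 1.7-fold lower number from compound 1 to compound 3 (0.23 log units; within the scatter) stays within the scatter too. A small move toward lower numbers, or none beyond the scatter, is therefore expected in this assay for this change. The estimate is a 1.2-fold lower number from compound 2 to compound 4 (0.08 log units; within the scatter) as the expected step. Compound 4 is estimated at 1700 nM within an expected range from 800 nM to 3600 nM as the likely span.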

Compound 4, half-maximal inhibitory concentration: 1860 nM
Beside the measured number, compound 4's estimate is 1.1-fold (0.04 log units) below it; measured number inside the range.
By their numbers in this assay, from the lowest: compounds 3, 4, 2 and 1 (each within the scatter of the next).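

In this assay, the change from 4-fluorophenyl to 4-(trifluoromethyl)phenyl has now been read at this second place in the molecule, giving a 1.1-fold lower number from compound 2 to compound 4 (0.04 log units; within the scatter). The replacement therefore leaves the number within the scatter at both places tested, and the two steps cannot be told apart: the same change on two cores in this assay, a 1.7-fold lower number (0.23 log units; within the scatter) from compound 1 to compound 3 and a 1.1-fold lower number (0.04 log units; within the scatter) from compound 2 to compound 4, 1.6-fold (0.19 log units) apart, within the scatter of two such steps

Only fluoro and trifluoromethyl stand at this position among the compounds shown. From the compounds shown here alone, how an amine or a carboxylic acid there would read in this assay stays open, so the range of this position remains untested by these compounds.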